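Urea aryl swap on the shared core: naphthyl to thienyl

This account rests on a few compounds, and the source may have more. Where it says the series, first, only, none or still open, it means among the compounds named here.

compound 1 `Cc1cc(C)cc(NC(=O)Nc2ccc(Nc3ncnc4c3OCCN4)cc2)c1` — 1070 nM
compound 2 `O=C(Nc1ccc(Nc2ncnc3c2OCCN3)cc1)Nc1cccc2ccccc12` — > 10000 nM

In an assay on isolated protein for inhibition of proto-oncogene tyrosine-protein kinase receptor Ret (Homo sapiens), read by 33P incorporation, with stated times of 15 min and 40 min (a lower number here means a stronger inhibitor, a higher number a weaker inhibitor), compound 2 gives only a limit, > 10000 nM. The limit of > 10000 nM in this assay, at which 1 of the 2 values shown sits, marks where compound 2 sits. For the measured compounds named here, compound 1 gives 1070 nM in this assay, and the one measured change on this nitrogen is an at least 9.3-fold higher number from compound 1 to compound 2 (0.97 log units; beyond the scatter). Compound 3 `O=C(Nc1ccc(Nc2ncnc3c2OCCN3)cc1)Nc1cccs1` carries thiophen-2-yl in place of naphthalen-1-yl on an amide-type nitrogen. Going by the values given here, as the one comparable step ran from a smaller aryl to the naphthyl with a weaker result, a move back to a small aryl is expected to lower the number in this assay, so for compound 3 the expected step is an at least 3.3-fold lower number from compound 2 to compound 3 (0.52 log units; beyond the scatter), though another limit remains possible. Compound 3 is estimated at 3000 nM (800 nM to 12000 nM).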

Compound 3, half-maximal inhibitory concentration: > 10000 nM
Compound 3: only a limit was reported; the forecaster's own chance of this, stated with the estimate: 25%; at least 3.3-fold (0.52 log units) between middle value and limit.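

Moving from naphthalen-1-yl to thiophen-2-yl on this amide-type nitrogen does not recover the activity of compound 1: in this assay, thiophen-2-yl in place of 3,5-dimethylphenyl gives an at least 9.3-fold higher number from compound 1 to compound 3 (0.97 log units; beyond the scatter). The step from compound 2 to compound 3 cannot be read, as both values are limits. Of the three aryl groups shown, only 3,5-dimethylphenyl gives a value that is not a limit, and the other two share one: the limit of > 10000 nM in this assay, at which 2 of the 3 values shown sit.

Going by these compounds, it remains open whether the two methyl groups of compound 1 are both needed. An unsubstituted phenyl or a phenyl carrying a single methyl or an amine would test this.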